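A few compounds are considered here, and "the series" means these few. Any claim that something is new, unique, unknown or untested is made for them only; others in the source may bear on it.

Compound 2 `CC(C)(C)C1=C(C(=O)O)N2C(=O)[C@H]([C@H](O)c3ccccc3)[C@H]2O1` and compound 1 `COC(=O)[C@@H](O)[C@H]1C(=O)N2C(C(=O)O)=C(C(C)(C)C)O[C@H]12` share one core and differ in a single place. In an ADME assay, in phosphate buffer, at 28 degrees C, at pH 7.0 (on this read-out higher numbers stand for a longer-lived compound and lower numbers for a shorter-lived compound), compound 2 gives 7 h, and compound 1 gives 6.2 h. These two numbers sit within the scatter of each other, so compound 2 cannot be called the longer-lived of the pair: the step of a 1.1-fold higher number from compound 1 to compound 2 (0.05 log units; within the scatter), which put a phenyl in place of a methoxycarbonyl on a saturated chain carbon bound to an oxygen on a saturated carbon and a saturated ring carbon, left the half-life essentially where it was.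

Compound 3 `CC(C)(C)C1=C(C(=O)O)N2C(=O)[C@H]([C@H](O)c3ccncc3)[C@H]2O1` is not yet measured. It differs from compound 2 in one place: pyridin-4-yl in place of phenyl on a saturated chain carbon bound to an oxygen on a saturated carbon and a saturated ring carbon. Going by the values given here, the only step seen so far, a 1.1-fold higher number from compound 1 to compound 2 (0.05 log units; within the scatter), already exchanged the group at this same place for one of a quite different kind without carrying the number beyond the scatter, and it is the one step that bears on the new change. It gives no sign that exchanging one six-membered aromatic ring for another would do more, so the estimated step of a 1.1-fold lower number from compound 2 to compound 3 (0.03 log units; within the scatter) is expected to stay within the scatter. For compound 3 in this assay the estimate is 6.5 h, with a range from 3.5 h to 12 h.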

Compound 3, half-life: 6.4 h
Beside the measured number, compound 3's estimate is 1.0-fold (0.01 log units) above it; measured number inside the range.
By their numbers in this assay, from the lowest: compounds 1, 3 and 2 (each within the scatter of the next).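

In this assay the new ring differs from phenyl by carrying one nitrogen among its six ring atoms and one hydrogen-bond acceptor, and this exchange on the saturated chain carbon gives no readable change in half-life (a 1.1-fold lower number from compound 2 to compound 3 (0.04 log units; within the scatter)). Set against the methoxycarbonyl group, pyridin-4-yl also stays within the scatter (a 1.0-fold higher number from compound 1 to compound 3 (0.01 log units; within the scatter)), so methoxycarbonyl, phenyl and pyridin-4-yl, three quite different groups at this one place, now all give half-lives that cannot be told apart, where earlier only two groups could be compared. No measurement is available that would explain why the half-life stays so level across these three compounds.

The compounds shown leave open whether any group at this place can move the half-life beyond the scatter, since only these three have been compared here, and an amine, a carboxylic acid or a longer chain could behave differently. They also leave open whether the same flat picture would hold with the shared core changed elsewhere, since all three compounds differ only at this one place.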